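This account rests on a few compounds, and the source may have more. Where it says the series, first, only, none or still open, it means among the compounds named here.

Measured so far:
Compound 1, `COC(=O)c1cc(NCc2ccccc2[N+](=O)[O-])c2cn[nH]c2c1`, gives 11% in an assay for inhibition of Indoleamine 2,3-dioxygenase 1 (Homo sapiens), with stated times of 10 min and 60 min, tested at 10 uM; on this read-out higher numbers stand for a stronger effect at the one concentration tested and lower numbers for a weaker effect.
Compound 2, `CNC(=O)c1cccc(CNc2cc(C(F)(F)F)cc3[nH]ncc23)c1`, gives 33% in this assay.

Compound 1 stands lowest of the two numbers; compound 2 sits higher by a gap beyond the usual scatter, so the two compounds are genuinely told apart. Compound 3, `O=[N+]([O-])c1ccccc1CNc1cc(C(F)(F)F)cc2[nH]ncc12`, has not yet been measured. It differs from compound 1 in one place: trifluoromethyl in place of methoxycarbonyl on an aromatic carbon. Going by the values given here, no pair of measured compounds shows this single change, so its size must be guessed. Compound 2 also carries a trifluoromethyl group and gives 33%, but it differs from compound 1 in more than one place, so it only hints at the direction. A small rise is expected for compound 3, with the step of a number 9 percentage points higher from compound 1 to compound 3 (within the scatter) expected to stay modest and possibly within the scatter. Compound 3 is estimated at 20%, within a range from 5% to 40%.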

Compound 3, a percentage reported as inhibition, at one concentration (the size of the read-out at that concentration, not a potency): 35%
Beside the measured number, compound 3's estimate is 15 percentage points below it, and the stated range covers the measured number.
By their numbers in this assay, from the lowest: compound 1; then compounds 2 and 3 (each within the scatter of the next).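

In this assay, trifluoromethyl in place of methoxycarbonyl on this aromatic carbon now has a size of its own, and the rest of the molecule stays the same: the change comes with a number 24 percentage points higher from compound 1 to compound 3 (beyond the scatter). Compound 2 could only hint at this, since it differs from compound 1 in more than one place. The group that leaves carries hydrogen-bond acceptors and the one that enters carries none, so for this pair, acceptors in this group are not needed for the higher read-out, although that read-out is an effect at one concentration, not a potency.

As far as these compounds go, it remains open how other groups on this same carbon would compare, such as a carboxylic acid, a nitrile or an amine. No measurement shown here tells why the read-out rises with this change.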